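The compounds below may be only part of what the source reports. "The series", "measured", "known", "first", "only" and "open" are said of these compounds alone.

Measured compounds in an assay for binding affinity to 5-hydroxytryptamine receptor 1F (Homo sapiens), read by radioligand binding; a lower number here means a stronger inhibitor, a higher number a weaker inhibitor:
compound 1 `CC(=O)Nc1cc2c(C3CCN(C)CC3)c[nH]c2cn1`, giving 210 nM;
compound 2 `CN1CCC(c2c[nH]c3ccc(NC(=O)c4cccc(F)c4)nc23)CC1`, giving 11 nM;
compound 3 `CCCC(=O)Nc1ccc2[nH]cc(C3CCN(C)CC3)c2n1`, giving 6.9 nM.

Compound 2 holds the second highest of the three numbers; compound 3 lies nearest, and compound 1 furthest, beyond the scatter. Compound 4 `CN1CCC(c2c[nH]c3ccc(NC(=O)C(C)(C)C)nc23)CC1` is not yet measured. The change from compound 2 to compound 4 is tert-butyl in place of 3-fluorophenyl on a carbonyl carbon. Going by the values given here, the one step that bears on it is a 1.6-fold lower number from compound 2 to compound 3 (0.20 log units; within the scatter), an alkyl in place of the aryl on the same carbonyl carbon; it stayed within the scatter. A second alkyl at the same place is therefore expected to give a step of a 1.2-fold lower number from compound 2 to compound 4 (0.09 log units; within the scatter) in this assay, with no direction beyond the scatter. Compound 4 is estimated at 9 nM, in the range 4 nM to 25 nM.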

Compound 4, inhibition constant: 62 nM
Beside the measured number, compound 4's estimate is 6.9-fold (0.84 log units) below it; measured number outside the range, above it.
By their numbers in this assay, from the lowest: compounds 3 and 2 (each within the scatter of the next); then compound 4; then compound 1.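

In this assay the alkyl group on the carbonyl carbon matters: tert-butyl gives a 5.6-fold higher number from compound 2 to compound 4 (0.75 log units; beyond the scatter) and a 9.0-fold higher number from compound 3 to compound 4 (0.95 log units; beyond the scatter) while propyl stays within the scatter of 3-fluorophenyl. Among these three compounds, replacing the aryl with an alkyl does not by itself set the number; the identity of the alkyl does. No evidence on hand accounts for the gap between propyl and tert-butyl. Open, going by these compounds, is whether a longer chain such as pentyl, or isopropyl, sides with propyl or with tert-butyl. Also open, on these data alone, is how an amine on the carbonyl carbon behaves.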